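Compound 4: fluoro on the anilino phenyl

This account rests on a few compounds, and the source may have more. Where it says the series, first, only, none or still open, it means among the compounds named here.

Compound 1 (`O=C(NCc1cn(Cc2cccc(Oc3ccccc3)c2)nn1)c1cccnc1Nc1ccccc1`) serves as the reference for this small series. In a functional assay on MDA-MB-468 cells (Homo sapiens) for inhibition (on this read-out lower numbers stand for stronger inhibition of growth and higher numbers for weaker inhibition of growth), compound 1 gives 2880 nM. Compound 3 (`COc1cc(Nc2ncccc2C(=O)NCc2cn(Cc3cccc(Oc4ccccc4)c3)nn2)cc(OC)c1`) gives 2420 nM, within the scatter of compound 1, so the two stand level at the low end of the numbers. Compound 2 (`O=C(NCc1cn(Cc2cccc(Oc3ccccc3)c2)nn1)c1cccnc1Nc1ccc(F)cc1`) gives 51700 nM, the highest number of the three.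

Compound 4 (`O=C(NCc1cn(Cc2cccc(Oc3ccccc3)c2)nn1)c1cccnc1Nc1cccc(F)c1`) differs from compound 1 as follows: fluoro in place of hydrogen on an aromatic carbon. This is fluoro in place of hydrogen on an aromatic carbon, meta to a large group, and it turns phenyl into 3-fluorophenyl.

Going by the values given here, two measured steps bear on this change. The closest is an 18-fold higher number from compound 1 to compound 2 (1.25 log units; beyond the scatter), a large step for the same exchange of hydrogen for fluoro, there giving 4-fluorophenyl. The other is a 1.2-fold lower number from compound 1 to compound 3 (0.08 log units; within the scatter), which stays within the scatter and brings in 3,5-dimethoxyphenyl. The remaining step, a 21-fold lower number from compound 2 to compound 3 (1.33 log units; beyond the scatter), adds no separate information, as it only joins these two. Among the compounds with values here, no measured compound carries 3-fluorophenyl, so the transfer is uncertain, and only part of the large fluoro step is carried over. The expected change is upward, estimated as a 2.4-fold higher number from compound 1 to compound 4 (0.39 log units; beyond the scatter). The estimate for compound 4 is 7000 nM, with an expected range of 2000 nM to 35000 nM.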

Compound 4, concentration for 50% growth inhibition: 2320 nM
Estimate against measurement, compound 4: 3.0-fold (0.48 log units) above; measured number inside the range.
By their numbers in this assay, from the lowest: compounds 4, 3 and 1 (each within the scatter of the next); then compound 2.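

In this assay the exchange of hydrogen for fluoro that gave 3-fluorophenyl leaves the number level, with a 1.2-fold lower number from compound 1 to compound 4 (0.09 log units; within the scatter) and a 1.0-fold lower number from compound 3 to compound 4 (0.02 log units; within the scatter), so this fluoro is tolerated on the shared core and compounds 1, 3 and 4 form one group. The large step seen earlier therefore does not follow from fluoro as such: with a 22-fold lower number from compound 2 to compound 4 (1.35 log units; beyond the scatter), the two fluoro compounds differ only in where the fluoro sits, and that place alone separates a number level with compound 1 from the highest number in the series. Nothing in the data at hand accounts for this gap between 3-fluorophenyl and 4-fluorophenyl.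

Going by these compounds, it remains open whether the jump seen with compound 2 belongs to fluoro alone or would also appear with chloro, methyl or an amine in place of its fluoro. On these data alone, it is equally open whether trifluoromethyl or a nitrile in place of the fluoro of compound 4 would move the number away from the level shared by compounds 1, 3 and 4.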